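From chloro to fluoro on one aromatic carbon

The source may report more compounds than this note shows. Statements on the series, on what has been measured and on what is new or still open speak of the compounds shown alone.

Measured compounds:
compound 1 `O=C1NC(=S)/C(=C/c2ccc(Cl)cc2)S1`: 10%
compound 2 `O=C1NC(=S)/C(=C/c2ccccc2Br)S1`: 13.3%
compound 3 `O=C1NC(=S)/C(=C/c2cccc(Cl)c2)S1`: 3.35%

In a functional assay on NCI-H292 cells (Homo sapiens) for cytotoxicity, read by MTT assay, with a stated time of 72 h, tested at 1.25 ug/mL (a higher number here means more inhibition of growth at the concentration tested, a lower number less inhibition of growth), compound 1 gives 10% and lies within the usual scatter of both compound 2 and compound 3, so it holds no distinct place among them. The values of compound 2 and compound 3 also lie within the scatter of each other, and the three cannot be ranked.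

Compound 4 `O=C1NC(=S)/C(=C/c2ccc(F)cc2)S1` has not yet been measured. Its change from compound 1 is fluoro in place of chloro on an aromatic carbon and amounts to fluoro in place of chloro on an aromatic carbon, with the shared core untouched. Among the compounds with values here, no measured pair isolates a single structural change, so the data give no direct precedent. Compound 1 at 10% is the closest reference, and no step beyond the scatter is expected in this assay, in either direction. The estimated change is a number 1 percentage points lower from compound 1 to compound 4 (within the scatter) and remains within the scatter. Compound 4 is expected at 9% with an estimated range from 0% to 22% in this measurement.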

Compound 4, percent growth inhibition at one concentration: 7.32%
Compound 4: middle estimate off by 1.7 percentage points, on the high side; the range from low to high includes it.
By their numbers in this assay, from the lowest: compounds 3, 4, 1 and 2 (each within the scatter of the next).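

In this assay, within the data shown here, fluoro in place of chloro on an aromatic carbon, para to a group of 8 heavy atoms, gives a number 2.7 percentage points lower from compound 1 to compound 4 (within the scatter) and provides the first comparison in this set that isolates a single change. At this position, the two halogens therefore cannot be told apart in this read-out at the one concentration tested. Nothing at hand bears on why the step is this small, so no explanation can be offered.

The compounds shown leave open whether a group of another kind at this same position, such as an amine, a carboxylic acid or a methoxy group, would shift the growth inhibition beyond the scatter. They also leave open whether compound 1 and compound 4 would separate at a higher concentration.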